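The source may report more compounds than this note shows. Statements on the series, on what has been measured and on what is new or still open speak of the compounds shown alone.

Working notes, a functional assay on HepG2 cells (Homo sapiens) for inhibition, read by MTT assay, with a stated time of 72 h; a lower number here means a stronger inhibitor, a higher number a weaker inhibitor:
- Compound 1 `COc1cc(O)c(CC=C(C)C)c(O)c1C(=O)/C=C/c1ccc(C(F)(F)F)cc1`: 6500 nM
- Compound 2 `COc1cc(OC)c(C(=O)/C=C/c2ccc(O)cc2)c(OC)c1`: 37000 nM

Compound 2 has the higher number of the two, making it the weaker inhibitor, and the gap to compound 1 lies beyond the scatter. Compound 3 `COc1cc(OC)c(C(=O)/C=C/c2ccc(Cl)cc2)c(OC)c1` differs from compound 2 by chloro in place of hydroxy on an aromatic carbon. The 4-hydroxyphenyl becomes 4-chlorophenyl, para to a large group. For the measured compounds named here, no measured pair shows this change, so the expectation is tentative. A small move towards a lower number is expected in this assay, possibly not beyond the scatter: the estimated step is a 1.9-fold lower number from compound 2 to compound 3 (0.27 log units; within the scatter). For compound 3 the expected value is 20000 nM, within an estimated range of 8000 nM to 45000 nM.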

Compound 3, half-maximal inhibitory concentration: 12400 nM
Estimate against measurement, compound 3: 1.6-fold (0.21 log units) above, and the stated range covers the measured number.
By their numbers in this assay, from the lowest: compounds 1 and 3 (each within the scatter of the next); then compound 2.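

In this assay, for the compounds shown here, replacing hydroxy with chloro on the aromatic carbon para to a large group gives the first single-place comparison, a 3.0-fold lower number from compound 2 to compound 3 (0.47 log units; beyond the scatter). At this position, the hydroxy is therefore not required for inhibition, and the 4-chlorophenyl compound keeps a modest gain over the 4-hydroxyphenyl compound. No available evidence bears on the reason for this step.

As far as these compounds go, whether a methoxy, a fluoro or an amine at this position would track with chloro or hydroxy remains open. Compound 1 differs from compound 2 and compound 3 in more than one place, so its separate groups cannot be assessed.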